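Chloro on the fused ring of a weak growth inhibitor

The source may report more compounds than this note shows. Statements on the series, on what has been measured and on what is new or still open speak of the compounds shown alone.

Among the measured compounds shown here, compound 2 `COc1ccc(C2=NN(C3=NC(=O)/C(=C4\C(=O)Nc5ccccc54)S3)C(c3ccc(OC)cc3)C2)cc1` gives 100000 nM in a functional assay on cells (Cancer cell lines, Homo sapiens) for cytotoxicity, read by sulforhodamine B assay, with a stated time of 48 h (a lower number here means a stronger inhibitor of growth, a higher number a weaker inhibitor of growth), the highest of the two numbers known; its nearest neighbour, compound 1 `COc1ccc(C2CC(c3ccccc3)=NN2C2=NC(=O)/C(=C3\C(=O)Nc4ccccc43)S2)cc1`, gives 1520 nM. For the measured compounds named here, the only measured step is a 66-fold higher number from compound 1 to compound 2 (1.82 log units; beyond the scatter), a methoxy added on an aromatic carbon. Going by the values given here, compound 3 `COc1ccc(C2=NN(C3=NC(=O)/C(=C4\C(=O)Nc5ccc(Cl)cc54)S3)C(c3ccc(OC)cc3)C2)cc1` differs from compound 2 by chloro in place of hydrogen on an aromatic carbon, a change no measured step addresses. With nothing to guide direction, the step of a 1.3-fold lower number from compound 2 to compound 3 (0.10 log units; within the scatter) is expected to stay within the scatter. Compound 3 is therefore estimated at 80000 nM, with a range from 20000 nM to 150000 nM.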

Compound 3, concentration for 50% growth inhibition: 250 nM
Beside the measured number, compound 3's estimate is 320-fold (2.51 log units) above it; the whole stated range lies above it.
By their numbers in this assay, from the lowest: compound 3; then compound 1; then compound 2.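

In this assay, among the compounds shown here, chloro in place of hydrogen on an aromatic carbon of the ring fused to the shared core brings a 400-fold lower number from compound 2 to compound 3 (2.60 log units; beyond the scatter), showing that this position, unchanged in the earlier compounds, responds strongly to a single heavy atom. Both methoxy groups stay in place, so this one change carries the whole step. No evidence at hand bears on why the step is so large.

From the compounds shown here alone, it remains open whether chloro would act the same way on compound 1. Also open, going by these compounds, is whether fluoro, methyl or an amine at this position would give a step of similar size.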